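From acetyl to 4-chlorophenyl on the nitrogen

The compounds below may be only part of what the source reports. "The series", "measured", "known", "first", "only" and "open" are said of these compounds alone.

Values so far in a functional assay on the whole organism with Mus musculus as the target; on this read-out higher numbers stand for an effect only at larger amounts of compound and lower numbers for an effect already at smaller amounts
- compound 1 `CC(C)=Cc1c(C)c(N)c(C)c2c1OC(C)(C)C2` gives 21.9 mg/kg
- compound 2 `Cc1c(C)c2c(c(C)c1N)CC(C)(CN1CCC(c3ccccc3)CC1)O2` gives 10.4 mg/kg
- compound 3 `CC(=O)Nc1c(C)c(C)c2c(c1C)CC(C)(C)O2` gives > 100 mg/kg as a limit of the assay

Compound 3 stands at > 100 mg/kg as a limit and not a number, the only such case among the three measured compounds.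

Compound 4 (`Cc1c(C)c2c(c(C)c1Nc1ccc(Cl)cc1)CC(C)(C)O2`) carries 4-chlorophenyl in place of acetyl on a nitrogen on an aromatic ring. Among the compounds with values here, no measured step covers this change. A sizeable step down in this assay is expected, toward an effect at smaller amounts, although a result that is again only a limit remains possible. This expectation rests on compound 1 at 21.9 mg/kg and compound 2 at 10.4 mg/kg with neither carrying acetyl or 4-chlorophenyl on that nitrogen. The expected step is an at least 2.8-fold lower number from compound 3 to compound 4 (0.45 log units; beyond the scatter) on this estimate. For compound 4 the estimated value is 35 mg/kg (expected range 10 mg/kg to 100 mg/kg).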

Compound 4, dose for 50% inhibition: > 50 mg/kg
Compound 4 was reported as a limit; the forecaster's own chance of this, stated with the estimate: 25%; at least 1.4-fold (0.15 log units) between middle value and limit.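

Within the data shown here, compound 3 and compound 4 are both reported only as limits, and no step between them can be read in this assay. The compounds shown leave open how far, and in which direction, 4-chlorophenyl in place of acetyl on a nitrogen on an aromatic ring shifts the read-out.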